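The compounds below may be only part of what the source reports. "The series", "measured", "known", "first", "only" and "open" are said of these compounds alone.

Three relatives of compound 4 have been tested in an ADME assay on KB cells (Homo sapiens) for cytotoxicity, read by MTT assay, with a stated time of 72 h; on this read-out higher numbers stand for lower toxicity in this test and lower numbers for higher toxicity in this test. Compound 1 `CCOc1ccc(-c2csc(Nc3ccc(Cl)cn3)n2)nc1` gives 2700 nM. Compound 2 `COc1ccc(-c2nc(Nc3ccc(Cl)cn3)sc2Cl)nc1` gives 248000 nM, a far higher number. Compound 3 `FC(F)(F)c1ccc(-c2nc(Nc3ccc(Cl)cn3)sc2Cl)nc1` gives > 400000 nM, which is a limit of the assay and not a number, so its place is known only as the limit of > 400000 nM in this assay, at which 1 of the 3 values shown sits.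

Compound 4 `CCOc1ccc(-c2nc(Nc3ccc(Cl)cn3)sc2Cl)nc1` has not yet been measured. It carries ethoxy in place of trifluoromethyl on an aromatic carbon.

Among the measured compounds shown here, the one measured step that bears on this is an at least 1.6-fold higher number from compound 2 to compound 3 (0.20 log units; that floor lies within the scatter), for trifluoromethyl in place of methoxy. Its floor lies within the scatter, so it fixes no clear size. A lower number is still expected, resting on compound 2 at 248000 nM and compound 1 at 2700 nM, which carry methoxy and ethoxy and both give real numbers in this assay. The expected change is an at least 3.0-fold lower number from compound 3 to compound 4 (0.48 log units; beyond the scatter), a modest step at most. Compound 4 is expected at 130000 nM, with an estimated range from 30000 nM to 400000 nM.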

Compound 4, half-maximal cytotoxic concentration in the KB assay: 12100 nM
Compound 4: middle estimate off by 11-fold (1.03 log units), on the high side; the measured number lies below the stated range.
By their numbers in the KB assay, from the lowest: compound 1; then compound 4; then compound 2. At a limit, above all of these: compound 3.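

In the KB assay, ethoxy in place of trifluoromethyl gives an at least 33-fold lower number from compound 3 to compound 4 (1.51 log units; beyond the scatter), and the starting point of that step is a limit of the assay, not a number. In the KB assay, one added methyl, which turns methoxy into ethoxy on the same chlorinated core, already gives a 20-fold lower number from compound 2 to compound 4 (1.31 log units; beyond the scatter), so this position responds strongly even to a very small change in the chain. With ethoxy held constant in the KB assay, chloro in place of hydrogen on the core gives a 4.5-fold higher number from compound 1 to compound 4 (0.65 log units; beyond the scatter), which shows that the added chloro and the added methyl move the number in opposite directions.

In a physicochemical assay for solubility, in phosphate buffer, with a stated time of 2 h, at pH 7.4 (a lower number here means a less soluble compound, a higher number a more soluble compound), compound 3 gives < 10000 nM, which is a limit of the assay and not a number. In the physicochemical assay compound 4 gives < 10000 nM, which is likewise a limit of the assay and not a number. Going by these compounds, the step in the physicochemical assay cannot be read because compound 3 and compound 4 both stand at a limit of the assay: the limit of < 10000 nM in the physicochemical assay, at which 2 of the 2 values shown sit. How a longer chain such as propoxy, or an amine, at this position would read in the KB assay remains open.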